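The source may hold more compounds than are shown below. What is called first, only, known or untested is meant among the compounds shown, and "the series" means these compounds.

Compound 1 `O=C(Nc1cccc(-n2cc(-c3ccncc3)c(-c3ccc(Cl)c(O)c3)n2)c1)Nc1ccc(Cl)c(Cl)c1` gives 1010 nM in a functional assay on KM12 cells (Homo sapiens) for inhibition, read by sulforhodamine B assay, with a stated time of 48 h (a lower number here means a stronger inhibitor of growth, a higher number a weaker inhibitor of growth), the second highest of the three numbers in hand. Compound 3 `O=C(Nc1cccc(-n2cc(-c3ccncc3)c(-c3ccc(Cl)c(O)c3)n2)c1)Nc1cc(C(F)(F)F)cc(C(F)(F)F)c1` gives 506 nM, a value within the scatter of compound 1, so no order between the two can be read. Compound 2 `COc1cc(-c2nn(-c3cccc(NC(=O)c4ccc(Cl)c(C(F)(F)F)c4)c3)cc2-c2ccncc2)ccc1Cl` gives 2060 nM, which lies beyond the scatter of compound 1. Compound 4 `O=C(Nc1cccc(-n2cc(-c3ccncc3)c(-c3ccc(Cl)c(O)c3)n2)c1)Nc1ccc(Cl)c(C(F)(F)F)c1` is not yet measured; it differs from compound 1 by trifluoromethyl in place of chloro on an aromatic carbon. Within the data shown here, no step between two measured compounds matching this change is available. In this assay the step from compound 1 to compound 4 is expected to be small, at most a modest move toward a lower number and possibly none beyond the scatter, as a 1.3-fold lower number from compound 1 to compound 4 (0.10 log units; within the scatter). Compound 4 is therefore expected to give about 800 nM in this assay, within a range from 350 nM to 1800 nM.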

Compound 4, concentration for 50% growth inhibition: 1000 nM
Estimate against measurement, compound 4: 1.3-fold (0.10 log units) below, and the stated range covers the measured number.
By their numbers in this assay, from the lowest: compounds 3, 4 and 1 (each within the scatter of the next); then compound 2.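

In this assay, among these compounds, the change from 3,4-dichlorophenyl to 4-chloro-3-(trifluoromethyl)phenyl gives a 1.0-fold lower number from compound 1 to compound 4 (0.00 log units; within the scatter) and is the first single-place step. At this place, ortho to a chloro group, four heavy atoms of trifluoromethyl thus stand in for the one of chloro with no readable change in growth inhibition. Nothing in hand gives a reason for this flat step. On these data alone, whether a nitrile, a methyl group or an amine at this place would stay equally flat remains open, as does whether the same change reads alike with the other parts of the molecule altered.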